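Thiazole series: replacing the furan-3-yl with pyridin-4-yl

The compounds below may be only part of what the source reports. "The series", "measured", "known", "first", "only" and "open" are said of these compounds alone.

Two compounds of the series have been run in an in vitro functional assay on HEK285-7 cells for antagonist activity at prostaglandin D2 receptor 2 (Homo sapiens), read by BRET and beta-arrestin recruitment (on this read-out lower numbers stand for stronger inhibition and higher numbers for weaker inhibition), so far. Within the data shown here, compound 1 `N#Cc1ccc(-c2nc(C(c3ccc(F)cc3)c3ccc(F)cc3)sc2CC(=O)O)cc1` gives 1500 nM in this assay, while compound 2 `O=C(O)Cc1sc(C(c2ccc(F)cc2)c2ccc(F)cc2)nc1-c1ccoc1` gives 130 nM, the lowest of the two numbers; the only measured step, a 12-fold lower number from compound 1 to compound 2 (1.06 log units; beyond the scatter), separates them. Compound 3 `O=C(O)Cc1sc(C(c2ccc(F)cc2)c2ccc(F)cc2)nc1-c1ccncc1` is the next candidate, differing from compound 2 by pyridin-4-yl in place of furan-3-yl on an aromatic carbon. Among the measured compounds shown here, the one step that bears on this position, a 12-fold lower number from compound 1 to compound 2 (1.06 log units; beyond the scatter), shows that a six-membered aromatic ring at this carbon gave a markedly higher number than the five-membered furan-3-yl, so a move back to a six-membered ring is expected to cost some of the gain, though pyridin-4-yl is not 4-cyanophenyl and the extent is uncertain. The expected step is a 3.1-fold higher number from compound 2 to compound 3 (0.49 log units; beyond the scatter) in this assay. Compound 3 is therefore estimated at 400 nM, with a range from 130 nM to 1300 nM.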

Compound 3, half-maximal inhibitory concentration: 40 nM
Estimate against measurement, compound 3: 10-fold (1.00 log units) above; measured number below the stated range.
By their numbers in this assay, from the lowest: compound 3; then compound 2; then compound 1.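

In this assay, pyridin-4-yl in place of furan-3-yl gives a 3.3-fold lower number from compound 2 to compound 3 (0.51 log units; beyond the scatter), so a six-membered aromatic ring at this carbon does not by itself raise the number. Pyridin-4-yl in place of 4-cyanophenyl gives a 38-fold lower number from compound 1 to compound 3 (1.57 log units; beyond the scatter), which puts the two six-membered rings at opposite ends of the three numbers, with the five-membered furan-3-yl in the middle, and ring size alone does not order this position. No supporting measurement bears on why these groups differ.

The compounds shown do not tell whether the ring nitrogen of pyridin-4-yl or the absence of the nitrile separates compound 3 from compound 1, a question that an unsubstituted phenyl at this carbon would address. On these data alone, whether a thiophene ring would behave like furan-3-yl also stays open.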